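Bromo-for-hydrogen step on the styryl ring of compound 1

The source may hold more compounds than are shown below. What is called first, only, known or untested is meant among the compounds shown, and "the series" means these compounds.

Two chalcones with hydroxyl and methoxy substitution have numbers in a functional assay on RAW264.7 cells (Mus musculus) for inhibition; on this read-out lower numbers stand for stronger inhibition and higher numbers for weaker inhibition. Compound 1 `COc1cccc(O)c1C(=O)/C=C/c1ccccc1` gives 9600 nM, the higher of the two numbers, which here means the weaker inhibition. Compound 2 `CC1(C)C=Cc2cc(C(=O)/C=C/c3ccc(O)cc3)c(O)cc2O1`, built on a different core, gives 2400 nM, a lower number that lies beyond the scatter of compound 1, so compound 2 is the stronger inhibitor of the pair. Among the compounds with values here, no two measured compounds differ in only one place, so no single measured step is available as a guide.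

Compound 3 `COc1cccc(O)c1C(=O)/C=C/c1cccc(Br)c1` keeps the core of compound 1 and differs from it in one place: bromo in place of hydrogen on an aromatic carbon. Within the data shown here, nothing among the measured compounds shows what a halogen on this ring does in this assay, so the step from compound 1 to compound 3 is expected to be small, most likely within the scatter, with a slight lean toward a lower number: the estimated step is a 1.6-fold lower number from compound 1 to compound 3 (0.20 log units; within the scatter). Compound 3 is accordingly expected to give about 6000 nM in this assay, with a plausible range from 2500 nM to 15000 nM.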

Compound 3, half-maximal inhibitory concentration: 7800 nM
Beside the measured number, compound 3's estimate is 1.3-fold (0.11 log units) below it, and the stated range covers the measured number.
By their numbers in this assay, from the lowest: compound 2; then compounds 3 and 1 (each within the scatter of the next).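

Bromo in place of hydrogen on an aromatic carbon of the styryl ring, meta to a large group, gives a 1.2-fold lower number from compound 1 to compound 3 (0.09 log units; within the scatter) in this assay, the first single-place step available in this series. On this read-out, compound 1 and compound 3 cannot be told apart, so this carbon accepts a bromine atom with no step beyond the scatter, which neither compound 1 nor compound 2 alone could show. Nothing in the available data bears on the reason for this outcome.

This single step covers only one substituent on one carbon of the ring and only the core of compound 1, so it cannot be read as a general statement about halogens or about substitution on this ring. Still open, going by these compounds, is whether a group of another kind at the same carbon, such as an amine, a carboxylic acid or a longer chain, would give a step beyond the scatter in this assay, and whether bromo on the other carbons of this ring would behave as it does here.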